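Methyl for hydrogen on the 2,3-dihydroxypropyl compound

A few compounds are considered here, and "the series" means these few. Any claim that something is new, unique, unknown or untested is made for them only; others in the source may bear on it.

So far the shared core has been measured in three compounds in a functional assay for inhibition, with Homo sapiens as the target; a higher number here means a weaker inhibitor, a lower number a stronger inhibitor. Compound 1 `CCCc1nc(C)c2c(C)nn(CC(=O)O)c(=O)n12` returns only > 48000 nM, which is a limit of the assay and not a number. Compound 2 `C=CCn1nc(C)c2c(C)nc(CCC)n2c1=O` has several entries, (the several entries of compound 2 in this assay, 69000 nM; > 48000 nM (2 entries)), and in this assay compound 2 gives 69000 nM; > 48000 nM (2 entries), of which only the first is a number. Compound 3 `CCCc1nc(C)c2cnn(CC(O)CO)c(=O)n12` returns > 48000 nM; this too is a limit of the assay and not a number. Compound 3 therefore stands at the limit, and the same limit holds two of the three values shown, (the limit of > 48000 nM in this assay, at which 2 of the 3 values shown sit), while the remaining entry carries no single number. Within the data shown here, nothing among the measured compounds rises above the floor of the assay.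

Compound 4 `CCCc1nc(C)c2c(C)nn(CC(O)CO)c(=O)n12` is the next compound in the series. It differs from compound 3 by methyl in place of hydrogen on an aromatic carbon. Among the measured compounds shown here, no step between two measured compounds is available to calibrate this change. With every measured compound at or close to the limit, the expectation for compound 4 is no step beyond the scatter in this assay, that is a step that the limit leaves unreadable from compound 3 to compound 4. Compound 4 is accordingly expected at 70000 nM, within 25000 nM to 250000 nM, and most likely reported only as a limit again.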

Compound 4, half-maximal inhibitory concentration: > 48000 nM
Compound 4 was reported as a limit; the forecaster's own chance of this, stated with the estimate: 70%; the middle value is on the limit's open side.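

In this assay compound 4 gives > 48000 nM, a limit of the assay and not a number. With compound 1 and compound 3 also reported as limits, neither step to compound 4 can be read. The compounds shown leave open how large the change from methyl in place of hydrogen is, and whether any compound on the shared core gives a value clear of the limit.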